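This account rests on a few compounds, and the source may have more. Where it says the series, first, only, none or still open, it means among the compounds named here.

The measured compounds are:

compound 1, `O=C(Nc1nc2ccc(Cl)cc2s1)c1cn(-c2ccccc2)nc1-c1ccccc1`, 7670 nM
compound 2, `O=C(Nc1nc2ccc(Cl)cc2s1)c1cn(-c2ccccc2)nc1-c1ccc(F)cc1`, 3870 nM
compound 3, `O=C(Nc1nc2ccccc2s1)c1cn(-c2ccccc2)nc1-c1ccc(Cl)cc1`, 10300 nM

All three were tested in a functional assay on A549 cells (Homo sapiens) for cytotoxicity, read by MTT assay, with a stated time of 72 h; a lower number here means a stronger inhibitor, a higher number a weaker inhibitor. Compound 1 and compound 2 share a core and differ by fluoro in place of hydrogen on an aromatic carbon, a change that gave a 2.0-fold lower number from compound 1 to compound 2 (0.30 log units; within the scatter). Compound 3 carries the same atoms as compound 1 joined differently; how the two cores differ is not broken down here. Compound 3 gives 10300 nM, which sits close to the number for compound 1 and further from the number for compound 2.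

Compound 4, `O=C(Nc1nc2ccc(F)cc2s1)c1cn(-c2ccccc2)nc1-c1ccc(Cl)cc1`, has not yet been measured. It is related to compound 3 by fluoro in place of hydrogen on an aromatic carbon. Within the data shown here, this is the same kind of change as the one from compound 1 to compound 2, but not the same: in compound 2 the fluorine sits on a six-membered aromatic ring of carbon only, para to a large group, whereas in compound 4 it sits on a six-membered aromatic ring of carbon only that is part of a fused system of two rings, meta to a fused ring and para to a fused ring.

For compound 4 in this assay, the expected step is a 1.6-fold lower number from compound 3 to compound 4 (0.20 log units; within the scatter), resting on the modest change seen in a 2.0-fold lower number from compound 1 to compound 2 (0.30 log units; within the scatter) and tempered by the different surroundings of the new fluorine. The estimate for compound 4 is therefore 6500 nM, with a range of 2500 nM to 16000 nM.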

Compound 4, half-maximal inhibitory concentration: 8860 nM
Estimate against measurement, compound 4: 1.4-fold (0.13 log units) below; measured number inside the range.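

In this assay, fluoro in place of hydrogen on an aromatic carbon gave a 1.2-fold lower number from compound 3 to compound 4 (0.07 log units; within the scatter), so the 1,3-benzothiazol-2-yl of compound 3 and the 6-fluoro-1,3-benzothiazol-2-yl of compound 4 cannot be told apart here. Set beside the earlier case, the change reads alike on the two cores, with no gap that stands out from the scatter: the same change on two cores in this assay, a 2.0-fold lower number (0.30 log units; within the scatter) from compound 1 to compound 2 and a 1.2-fold lower number (0.07 log units; within the scatter) from compound 3 to compound 4, 1.7-fold (0.23 log units) apart, within the scatter of two such steps. Among these compounds, this shows only that the change stayed small in both pairs; since neither step lies beyond the scatter and the fluorine sits on a different ring in each pair, it does not show that fluoro has a real effect in either pair, nor that the change would carry over to other cores.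

The compounds shown leave open whether a different group on the same aromatic carbon of the 1,3-benzothiazol-2-yl, such as methoxy, an amine or a carboxylic acid, would give a step beyond the scatter. They also leave open whether the change behaves the same way on any cell line other than the one used here.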